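Geometry of the butenyl linker: compound 3 to compound 4

This account rests on a few compounds, and the source may have more. Where it says the series, first, only, none or still open, it means among the compounds named here.

Among the compounds with values here, compound 3 `O=C1c2ccccc2C(=O)N1C/C=C\Cn1cc(C#CCCc2ccccc2)c(=O)[nH]c1=O` is the one member of the set with a number in a functional assay on L1210 cells (Mus musculus) for antiproliferative activity, read by MTT assay, with a stated time of 2 days (a higher number here means a weaker inhibitor, a lower number a stronger inhibitor), where compound 3 gives 143000 nM. Compound 1 `CCCCCCCCC#Cc1cn(C/C=C/CN2C(=O)c3ccccc3C2=O)c(=O)[nH]c1=O` returns only a limit in this assay, > 250000 nM. Compound 2 `CCCCCC#Cc1cn(C/C=C/CN2C(=O)c3ccccc3C2=O)c(=O)[nH]c1=O` likewise returns only a limit, > 500000 nM. The step from compound 1 to compound 2 is a step that the two limits leave unreadable from compound 1 to compound 2, so it tells nothing about size. Compound 4 `O=C1c2ccccc2C(=O)N1C/C=C/Cn1cc(C#CCCc2ccccc2)c(=O)[nH]c1=O` differs from compound 3 as follows: the two compounds have the same atoms and bonds and differ only in configuration as drawn: 1 of 1 stereo elements differ; a double bond is drawn Z in compound 3 and E in compound 4. Within the data shown here, no measured step in this assay addresses a change of double-bond geometry, so no direction can be read from the data. The number expected for compound 4 is therefore set close to compound 3, at 200000 nM (range 70000 nM to 600000 nM), which means an expected step of a 1.4-fold higher number from compound 3 to compound 4 (0.15 log units; within the scatter).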

Compound 4, half-maximal inhibitory concentration: 44000 nM
Estimate against measurement, compound 4: 4.5-fold (0.66 log units) above; measured number outside the range, below it.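

In this assay double-bond geometry alone gives a readable step, a 3.3-fold lower number from compound 3 to compound 4 (0.51 log units; beyond the scatter), and the pair offers no other difference: the fact that compounds 3 and 4 differ only in the configuration as drawn. With the E double bond held, phenyl in place of propyl gives an at least 11-fold lower number from compound 2 to compound 4 (1.05 log units; beyond the scatter), and phenyl in place of hexyl gives an at least 5.6-fold lower number from compound 1 to compound 4 (0.75 log units; beyond the scatter). Each of these two steps starts from a limit, not a number, so only a minimum size can be read.

Still open, as far as these compounds go, is whether the geometry step recurs with the propyl or hexyl chains. Also open, from the compounds shown here alone, is whether an amine or a carboxylic acid on the phenyl retains the activity of compound 4.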